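Stepping from compound 1 to compound 4

The source may hold more compounds than are shown below. What is called first, only, known or untested is meant among the compounds shown, and "the series" means these compounds.

Of the compounds shown here, three have been measured in an ADME assay on cells (Hepatocyte, Homo sapiens) for metabolic stability, with a stated time of 30 min; a lower number here means that less of the compound is left, a higher number that more of the compound is left. Compound 1 `O=C(NC1CCC(CN2CCN(c3cc(=O)c4cc(C(F)(F)F)cc([N+](=O)[O-])c4s3)CC2)CC1)c1ccccc1` gives 92.9%, the highest of the three numbers. Compound 3 `Nc1cc(C(F)(F)F)cc2c(=O)cc(N3CCN(CC4CCC(O)CC4)CC3)sc12` gives 72.9%, which is lower than the top number by more than the usual scatter. Compound 2 `O=c1cc(N2CCN(CC3CCCCC3)CC2)sc2c(NO)cc(C(F)(F)F)cc12` gives 19.1%, the lowest number, and it also lies beyond the scatter from the top number.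

Compound 4 `O=c1cc(N2CCN(CC3CCCCC3)CC2)sc2c([N+](=O)[O-])cc(C(F)(F)F)cc12` has not yet been measured. It departs from compound 1 in one place: hydrogen in place of benzamido on a saturated ring carbon.

Among the compounds with values here, no two measured compounds differ in just one place, so this step has no direct precedent. The nearest guide is compound 2, whose saturated ring also lacks a group at that carbon and which gives 19.1% in this assay, although it differs from compound 4 elsewhere too. A fall beyond the scatter is therefore expected, with considerable uncertainty about its size. The expected step is a number 47.9 percentage points lower from compound 1 to compound 4 (beyond the scatter). For compound 4 the estimated value is 45%, with an expected range of 20% to 72%.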

Compound 4, percent of the compound remaining: 82.4%
For compound 4 the middle estimate is 37.4 percentage points below the measured one, and the stated range ends below it.
By their numbers in this assay, from the lowest: compound 2; then compounds 3 and 4 (each within the scatter of the next); then compound 1.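

In this assay, hydrogen in place of benzamido on a saturated ring carbon gives a number 10.5 percentage points lower from compound 1 to compound 4 (beyond the scatter), a modest step, so at this position in these two compounds the large benzamido group can go while the number stays high. Nitro in place of hydroxyamino on an aromatic carbon gives a number 63.3 percentage points higher from compound 2 to compound 4 (beyond the scatter), a large step, which shows that the low number of compound 2 goes with the hydroxyamino group and not with the saturated ring lacking a group at that carbon, a separation the earlier compounds could not make. Nothing measured here bears on why either step has its size.

Going by these compounds, compound 3 differs from the others in more than one place, with amino on the aromatic carbon and hydroxyl on the saturated ring, so the separate contribution of each of those groups remains open. Also open, on these data alone, is how the number responds to other groups on that saturated ring carbon, such as an acetamido group or a carboxylic acid, and so whether the modest step holds beyond benzamido and hydrogen.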